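Acetyl Nitrogen Meets 2-Nitrophenyl Ring Carbon

The source may hold more compounds than are shown below. What is called first, only, known or untested is meant among the compounds shown, and "the series" means these compounds.

Measured compounds in a functional assay on the whole organism (plasma, strain albino) for inhibition, with Rattus norvegicus as the target, with stated times of 1 h and 4 h, at a dose of 50 mg/kg by the oral route; a higher number here means a stronger effect of the compound at the dose given, a lower number a weaker effect:
compound 1 `COc1ccc(Cl)cc1C(=O)Nc1ccc(C2=NN(C)C(c3ccccc3[N+](=O)[O-])C2)cc1` gives 91.3%
compound 2 `COc1ccc(Cl)cc1C(=O)Nc1ccc(C2=NN(c3ccccc3)C(c3ccccc3[N+](=O)[O-])C2)cc1` gives 84.4%
compound 3 `COc1ccc(C2CC(c3ccc(NC(=O)c4cc(Cl)ccc4OC)cc3)=NN2C(C)=O)cc1` gives 88.4%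

Compound 3 stands second highest of the three numbers, though its gaps to compound 1 and to compound 2 both lie within the scatter. Within the data shown here, the one measured step, a number 6.9 percentage points lower from compound 1 to compound 2 (within the scatter), concerns a different place, the amine nitrogen in the ring, and is itself within the scatter.

Compound 4 `COc1ccc(Cl)cc1C(=O)Nc1ccc(C2=NN(C(C)=O)C(c3ccccc3[N+](=O)[O-])C2)cc1` arises from compound 3 by 2-nitrophenyl in place of 4-methoxyphenyl on a saturated ring carbon. Among the measured compounds shown here, no measured step touches this position, so the data offer only the observation that compounds 1, 2 and 3 all sit close together in this assay regardless of which aryl group occupies that ring carbon and which group sits on the ring nitrogen. The step of a number 0.4 percentage points lower from compound 3 to compound 4 (within the scatter) is therefore expected to stay within the scatter, with no direction favoured. Compound 4 is estimated at 88%, with a range from 78% to 95%.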

Compound 4, a percentage reported as inhibition, in the whole organism at one dose (the size of the read-out at that dose, not a potency): 87.2%
Beside the measured number, compound 4's estimate is 0.8 percentage points above it, and the stated range covers the measured number.
By their numbers in this assay, from the lowest: compounds 2, 4, 3 and 1 (each within the scatter of the next).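

In this assay, among these compounds, the step of a number 1.2 percentage points lower from compound 3 to compound 4 (within the scatter) gives the first reading at this position: with acetyl held on the ring nitrogen, 2-nitrophenyl in place of 4-methoxyphenyl on a saturated ring carbon stays within the scatter. Compound 4 also completes a set on the ring nitrogen with 2-nitrophenyl held constant, and neither a number 2.8 percentage points higher from compound 2 to compound 4 (within the scatter), for acetyl in place of phenyl, nor a number 4.1 percentage points lower from compound 1 to compound 4 (within the scatter), for acetyl in place of methyl, can be told from the scatter. Nothing at hand explains these readings.

On these data alone, it remains open whether a carboxylic acid or an amine on the aryl ring at that saturated ring carbon, or a longer acyl chain on the ring nitrogen, would give a step beyond the scatter. Readings at one dose show only the size of the effect at that dose.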